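Three dithiocarbamates at the cytotoxicity limit, one untested

The source may hold more compounds than are shown below. What is called first, only, known or untested is meant among the compounds shown, and "the series" means these compounds.

Compound 1, `CN(C)C(=S)SC(=S)N1CCCCC1`: in an ADME assay on HeLa cells (Homo sapiens) for cytotoxicity, read by MTT assay, with a stated time of 24 h (a lower number here means a stronger inhibitor, a higher number a weaker inhibitor), compound 1 gives > 5000000 nM, a limit of the assay and not a number.
Compound 2, `CN(C)C(=S)SC(=S)N1CCN(c2ncccn2)CC1`: in this assay compound 2 gives > 5000000 nM, also a limit.
Compound 3, `CN(C)C(=S)SC(=S)N1CCN(C(=S)SCCCC#N)CC1`: in this assay compound 3 gives > 5000000 nM, again a limit.

Compound 3 therefore stands nowhere distinct among its companions: its value is a limit, and the values of compound 1 and compound 2 are limits as well, so none of the three can be ordered against another. This is summed up in the limit of > 5000000 nM in this assay, at which 3 of the 3 values shown sit. Among the measured compounds shown here, no step between measured compounds can be read from these data.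

Compound 4, `CN(C)C(=S)SC(=S)N1CCN(C(=S)NC2CCCCC2)CC1`, differs from compound 3 in one place: cyclohexylamino in place of (3-cyanopropyl)sulfanyl on a thiocarbonyl carbon. Every value for compound 1, compound 2 and compound 3 is a limit; they offer no gauge of how this change moves the read-out. For compound 4 the expected step is a number no higher from compound 3 to compound 4 (the limit leaves the size open), none beyond the scatter, with the assay most likely reporting only a limit once more. For compound 4 the estimated value in this assay is 5000000 nM, with a range from 2000000 nM to 20000000 nM.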

Compound 4, half-maximal inhibitory concentration: > 5000000 nM
Compound 4: no number, only a limit; the forecaster's own chance of this, stated with the estimate: 85%; the middle value sits exactly at the limit.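

Among the compounds shown here, compound 3 and compound 4 both stand at a limit in this assay, so no step between them can be read. The compounds shown leave open whether cyclohexylamino in place of (3-cyanopropyl)sulfanyl changes the read-out at all, and how they would rank, with every value so far sitting at one limit: the limit of > 5000000 nM in this assay, at which 4 of the 4 values shown sit.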